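A Thiophen-2-yl Analogue of Compound 1 in Growth Inhibition

This account rests on a few compounds, and the source may have more. Where it says the series, first, only, none or still open, it means among the compounds named here.

Compound 1 `COc1cc(/C=C/C(=O)/C=C/c2cc(OC)c(OC)c(OC)c2)ccc1OCc1cn(CCOc2cc(=O)oc3ccccc23)nn1` has been tested in a functional assay on HCT-116 cells (Homo sapiens) for inhibition, read by sulforhodamine B assay, with a stated time of 48 h, tested at 50 uM (on this read-out lower numbers stand for less inhibition of growth and higher numbers for more inhibition of growth at the one concentration tested), where compound 1 gives 89%. That is the higher of the two numbers recorded so far. Within the data shown here, the only other measured compound, compound 2 `COc1cc(/C=C/C(=O)/C=C/c2ccco2)ccc1OCc1cn(CCCCOc2cc(=O)oc3ccccc23)nn1`, gives 47% in this assay, a figure far below that of compound 1 and beyond the scatter. Among the measured compounds shown here, compound 2 differs from compound 1 in more than one place, so the pair shows only that their values lie far apart.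

Compound 3 `COc1cc(/C=C/C(=O)/C=C/c2cccs2)ccc1OCc1cn(CCOc2cc(=O)oc3ccccc23)nn1` has not yet been measured in this assay. It differs from compound 1 in one place: thiophen-2-yl in place of 3,4,5-trimethoxyphenyl on a double-bonded chain carbon bound to a double-bonded chain carbon. For the measured compounds named here, no measured pair isolates this change. Compound 2, which gives 47%, carries a five-membered ring at the same place but also a different linker, so it is only a loose guide. A downward step is expected, estimated at a number 29 percentage points lower from compound 1 to compound 3 (beyond the scatter). Compound 3 is therefore expected to give about 60% in this assay, within a range from 35% to 85%.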

Compound 3, percent growth inhibition at one concentration: 71%
The estimate for compound 3 lay 11 percentage points below the measured number, within the range that was stated.
By their numbers in this assay, from the lowest: compound 2; then compound 3; then compound 1.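

Thiophen-2-yl in place of 3,4,5-trimethoxyphenyl on a double-bonded chain carbon bound to a double-bonded chain carbon gives the first reading of a single change at this position: in this assay it amounts to a number 18 percentage points lower from compound 1 to compound 3 (beyond the scatter) for the swap. Growth inhibition therefore does not rest wholly on the 3,4,5-trimethoxyphenyl group, since compound 3, with 1 hydrogen-bond acceptor in place of 3 at this position, still gives 71% at the one concentration tested. Nothing measured here explains the size of this step.

Going by these compounds, whether an amine or a carboxylic acid on a phenyl ring at this position would bring the number nearer to that of compound 1 remains open. Also open, on these data alone, is whether the same swap gives a step of like size in a compound with a longer chain elsewhere.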